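A few compounds are considered here, and "the series" means these few. Any claim that something is new, unique, unknown or untested is made for them only; others in the source may bear on it.

Compound 1 `COc1ccc(-n2nncc2CN2C(=O)C3(C(C#N)=C(N)Oc4c3c3nc5ccccc5nc3c3ccccc43)c3ccccc32)cc1`: in a functional assay on A549 cells (Homo sapiens) for antiproliferative activity, read by MTT assay, with a stated time of 48 h (a higher number here means a weaker inhibitor, a lower number a stronger inhibitor), compound 1 gives > 50000 nM, which is a limit of the assay and not a number.
Compound 2 `N#CC1=C(N)Oc2c(c3nc4ccccc4nc3c3ccccc23)C12C(=O)N(Cc1cnnn1-c1ccc(S(N)(=O)=O)cc1)c1ccccc12`: in this assay compound 2 gives > 50000 nM, again a limit rather than a number.
Compound 3 `Cc1ccccc1-n1nncc1CN1C(=O)C2(C(C#N)=C(N)Oc3c(N)cc4nc5ccccc5nc4c32)c2ccccc21`: in this assay compound 3 gives 31700 nM.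

Compound 3 therefore stands as the only one of the three with an actual number; the other two values sit at the limit of > 50000 nM in this assay, at which 2 of the 3 values shown sit, so no order among the three can be read, and all of them count as weak inhibitors.

Compound 4 `CCc1cccc(CC)c1-n1nncc1CN1C(=O)C2(C(C#N)=C(N)Oc3c(N)cc4nc5ccccc5nc4c32)c2ccccc21` differs from compound 3 in a single place: 2,6-diethylphenyl in place of 2-methylphenyl on an aromatic nitrogen. Among the compounds with values here, the only measured step, a step that the two limits leave unreadable from compound 1 to compound 2, is left without a size by its two limits and concerns a different kind of group at a different place, so it gives neither a size nor a direction that could be carried over. With nothing to lean on, the change is expected to leave the activity roughly where compound 3 stands, an expected step of a 1.1-fold higher number from compound 3 to compound 4 (0.04 log units; within the scatter), that is, nothing beyond the usual scatter. Compound 4 is thus estimated at 35000 nM, with a likely range from 12000 nM to 90000 nM, and with a real chance that the assay again reports only a limit.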

Compound 4, half-maximal inhibitory concentration: > 50000 nM
Compound 4 ended at the assay's limit; the forecaster's own chance of this, stated with the estimate: 35%; at least 1.4-fold (0.15 log units) between middle value and limit.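

Within the data shown here, replacing 2-methylphenyl with 2,6-diethylphenyl on the aromatic nitrogen gives the first step at this position that can be read at all in this assay: an at least 1.5-fold higher number from compound 3 to compound 4 (0.19 log units; that floor lies within the scatter). Only a floor is known for this step, and that floor lies within the scatter, so the result does not establish a real loss of activity; it shows only that going from 7 to 10 heavy atoms in this group, with two ethyl groups in place of one methyl, brought no visible gain. With compound 4, whose value is again a limit and not a number, compound 3 remains the only compound with a real number, and the readings gather at one limit: the limit of > 50000 nM in this assay, at which 3 of the 4 values shown sit.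

The compounds shown leave open whether any group on this nitrogen can bring the activity clear of the limit, for example a plain phenyl, a benzyl, or a phenyl ring carrying an amine or a carboxylic acid. On these data alone, they also cannot tell how far past its limit compound 4 really lies, so the true size of this step remains unknown.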